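Swapping Butoxy for Benzyl on a Shared Core

A few compounds are considered here, and "the series" means these few. Any claim that something is new, unique, unknown or untested is made for them only; others in the source may bear on it.

Compound 2 `CCCCOc1ccc(NC(=O)n2nc(N)c3ccccc32)cc1`, compound 1 `COc1ccc(NC(=O)Nc2n[nH]c3ccccc23)cc1` and compound 3 `Nc1nn(C(=O)Nc2c(F)cccc2F)c2ccccc12` share a common core and were tested in a functional assay on Hs-578T cells (Homo sapiens) for inhibition, read by sulforhodamine B assay, with a stated time of 48 h; on this read-out lower numbers stand for stronger inhibition of growth and higher numbers for weaker inhibition of growth. Compound 2 gives 20200 nM. Compound 3 gives 73000 nM, which lies beyond the usual scatter above compound 2, so compound 2 holds the lowest of the two numbers. Compound 1 gives in this assay only a limit, > 100000 nM, namely (the limit of > 100000 nM in this assay, at which 1 of the 3 values shown sits). No two of these compounds differ in a single place, so no measured step is available to lean on.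

Compound 4 `Nc1nn(C(=O)Nc2ccc(Cc3ccccc3)cc2)c2ccccc12` has not yet been tested. It differs from compound 2 in one spot: benzyl in place of butoxy on an aromatic carbon. Within the data shown here, with no measured step of this kind to guide it, the expected step of a 1.3-fold lower number from compound 2 to compound 4 (0.13 log units; within the scatter) is an estimate of a small change, not clearly beyond the scatter in either direction. Compound 4 is therefore expected to give about 15000 nM, within a range from 4000 nM to 60000 nM.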

Compound 4, concentration for 50% growth inhibition: 17200 nM
Compound 4: the middle estimate sits 1.1-fold (0.06 log units) below what was measured; low and high end bracket the measured number.
By their numbers in this assay, from the lowest: compounds 4 and 2 (each within the scatter of the next); then compound 3. At a limit, above all of these: compound 1.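

The swap gives the first measured step among these compounds: in this assay, benzyl in place of butoxy on an aromatic carbon, para to a large group, gives a 1.2-fold lower number from compound 2 to compound 4 (0.07 log units; within the scatter) and so leaves the number where it was. This position therefore accepts a group carrying an aromatic ring of carbon only in place of an open chain with an oxygen, with no change that can be told from ordinary repeat variation. Nothing measured here tells why the two groups read alike.

Butoxy and benzyl both carry no net charge and no hydrogen-bond donor, so it stays open whether an amine or a carboxylic acid at this position would shift the number. On these data alone, the effect of a longer chain here, and whether the same swap holds on other cell lines, also stays open.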